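Three Limits and a Phenyl Exchange

The source may report more compounds than this note shows. Statements on the series, on what has been measured and on what is new or still open speak of the compounds shown alone.

Of the compounds shown here, three have been measured in an ADME assay on HCT-116 cells (Homo sapiens) for cytotoxicity, read by CellTiter-Glo, with a stated time of 72 h (a higher number here means a weaker inhibitor, a lower number a stronger inhibitor), and none of them has yet given an exact number. Compound 1 (`CC1CCN(C2CCN(S(=O)(=O)c3cccnc3Cl)CC2)CC1`) reaches only a limit, > 10000 nM. Compound 2 (`CC1CCN(C2CCN(S(=O)(=O)c3ccc(Br)cc3OC(F)(F)F)CC2)CC1`) also reaches only a limit, > 5000 nM. Compound 3 (`Cc1cc(C)c(S(=O)(=O)N2CCC(c3ccccc3)CC2)c(C)c1`) likewise stops at a limit, > 5000 nM. Compound 3 therefore has no exact place among the three, as the other two values are limits too.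

Compound 4 (`CCCC(=O)NC1CCN(S(=O)(=O)c2c(C)cc(C)cc2C)CC1`) carries (propylcarbonyl)amino in place of phenyl on a saturated ring carbon. Among the measured compounds shown here, no measured step between these compounds shows what such a change does. The expectation rests on compound 3, which holds the limit of > 5000 nM. In this assay, the expected step that the limit leaves unreadable from compound 3 to compound 4 stays within the usual scatter, with no firm direction. For compound 4 the estimated value is 8000 nM, with an expected range of 4000 nM to 20000 nM, and a reported limit rather than a number is the likelier outcome.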

Compound 4, half-maximal inhibitory concentration: > 5000 nM
Compound 4: only a limit was reported; the forecaster's own chance of this, stated with the estimate: 80%; the middle value is on the limit's open side.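

In this assay, among the compounds shown here, compound 3 and compound 4 both stop at a limit rather than a number, so no step between them can be read. The compounds shown leave open what (propylcarbonyl)amino in place of phenyl on a saturated ring carbon does to the exact value.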